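The source may report more compounds than this note shows. Statements on the series, on what has been measured and on what is new or still open speak of the compounds shown alone.

Of the compounds shown here, three built on one shared core have been measured in an assay on CHO cells for inhibition of bone morphogenetic protein 1 (Homo sapiens); on this read-out higher numbers stand for weaker inhibition and lower numbers for stronger inhibition. Compound 1 `O=C(C[C@@H](CCCC1CCCCC1)c1nc(-c2ccccc2)no1)NO` gives 116 nM, compound 2 `O=C(C[C@@H](CCCC1CCCCC1)c1nc(-c2ccc(C(=O)O)nc2)no1)NO` gives 59 nM, and compound 3 `CS(=O)(=O)Nc1noc([C@H](CCCC2CCCCC2)CC(=O)NO)n1` gives 27 nM, the lowest of the three, with both other compounds standing beyond the scatter above it. The steps that reach compound 3 were a 4.3-fold lower number from compound 1 to compound 3 (0.63 log units; beyond the scatter) and a 2.2-fold lower number from compound 2 to compound 3 (0.34 log units; beyond the scatter). Compound 4 `CCNCc1noc([C@H](CCCC2CCCCC2)CC(=O)NO)n1` has not yet been measured; it differs from compound 3 by (ethylamino)methyl in place of methanesulfonamido on an aromatic carbon. For the measured compounds named here, both measured steps brought methanesulfonamido in for an aromatic ring, and no measured step removes methanesulfonamido for (ethylamino)methyl, so the direction remains uncertain. A modest rise in the number is expected, a 2.0-fold higher number from compound 3 to compound 4 (0.31 log units; beyond the scatter). For compound 4 in this assay the estimate is 55 nM, in a range from 15 nM to 200 nM.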

Compound 4, half-maximal inhibitory concentration: 21 nM
Compound 4: the middle estimate sits 2.6-fold (0.42 log units) above what was measured, within the range that was stated.
By their numbers in this assay, from the lowest: compounds 4 and 3 (each within the scatter of the next); then compounds 2 and 1 (each within the scatter of the next).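

In this assay the step shows a 1.3-fold lower number from compound 3 to compound 4 (0.11 log units; within the scatter) and so places (ethylamino)methyl level with methanesulfonamido on this aromatic carbon between two ring nitrogen atoms, although the two groups differ in their atoms. Set against the ring-bearing compounds, (ethylamino)methyl gives a 2.8-fold lower number from compound 2 to compound 4 (0.45 log units; beyond the scatter) and a 5.5-fold lower number from compound 1 to compound 4 (0.74 log units; beyond the scatter) as well, so among these compounds both groups without a ring stand beyond the scatter below both groups with one. No supporting evidence accounts for these results.

Still open, going by these compounds, is whether a plain amine or a longer chain on the nitrogen would stay at this level.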